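The source may report more compounds than this note shows. Statements on the series, on what has been measured and on what is new or still open speak of the compounds shown alone.

Compound 1 `COC(=O)/C=C/c1cccc(N(Cc2ccc(-c3cccc(Cl)c3)cc2)C(=O)C2CCCCC2)c1` — 94 nM
Compound 2 `COC(=O)/C=C/c1cccc(N(Cc2ccc(-c3ccc(SC)cc3)cc2)C(=O)C2CCCCC2)c1` — 69 nM

For the measured compounds named here, in an assay on isolated protein with Bile acid receptor (Homo sapiens) as the target (on this read-out lower numbers stand for an effect already at smaller amounts and higher numbers for an effect only at larger amounts of compound), compound 2 gives 69 nM, and the only comparison at hand, a 1.4-fold lower number from compound 1 to compound 2 (0.13 log units; within the scatter), shows the two compounds sitting within the scatter of each other. Compound 3 `COC(=O)/C=C/c1cccc(N(Cc2ccc(/C=C/c3ccc(F)cc3)cc2)C(=O)C2CCCCC2)c1` differs from compound 2 by 2-(4-fluorophenyl)ethenyl in place of 4-(methylsulfanyl)phenyl on an aromatic carbon. Going by the values given here, the one measured step also exchanged the group at this same place, and it stayed within the scatter, so no step beyond the scatter is expected here either: the estimated step is a 1.1-fold higher number from compound 2 to compound 3 (0.04 log units; within the scatter). Compound 3 is therefore expected at about 75 nM, with a range from 25 nM to 220 nM.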

Compound 3, half-maximal effective concentration: 185 nM
For compound 3 the middle estimate is 2.5-fold (0.39 log units) below the measured one; measured number inside the range.
By their numbers in this assay, from the lowest: compounds 2, 1 and 3 (each within the scatter of the next, the first and the last beyond it).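

In this assay this place on the aromatic ring now shows a step beyond the scatter: 2-(4-fluorophenyl)ethenyl in place of 4-(methylsulfanyl)phenyl brings a 2.7-fold higher number from compound 2 to compound 3 (0.43 log units; beyond the scatter) and so shows that the group here can matter, though only modestly. Set against 3-chlorophenyl, the same group brings a 2.0-fold higher number from compound 1 to compound 3 (0.29 log units; within the scatter) and stays within the scatter, so the reading depends on the group it replaces. Nothing at hand explains why this exchange shifts the number.

The compounds shown leave open whether the double bond or the fluorine goes with the higher number. They also leave open how an amine or a carboxylic acid on the outer ring would read at this place.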